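Swapping chloro for methoxy on a cyanopyridine amide

The compounds below may be only part of what the source reports. "The series", "measured", "known", "first", "only" and "open" are said of these compounds alone.

compound 1 `C[C@@]1(c2cc(NC(=O)c3ncc(C#N)cc3Cl)ccc2F)C=C(CF)OC(N)=N1` gives 30.6 mL/min/kg
compound 2 `C[C@@]1(c2cc(NC(=O)c3ccc(C#N)cn3)ccc2F)C=C(CF)OC(N)=N1` gives 16.8 mL/min/kg
compound 3 `C[C@@]1(c2cc(NC(=O)c3coc(CF)n3)ccc2F)C=C(CF)OC(N)=N1` gives 55 mL/min/kg

These are readings from an ADME assay on the whole organism (strain Sprague-Dawley) for pharmacokinetics, with Rattus norvegicus as the target, read by LC-MS, using cassette dosing, at a dose of 0.5 mg/kg by the intravenous route (on this read-out lower numbers stand for slow clearance and higher numbers for fast clearance), for three compounds that share one core and differ in the group on the amide carbonyl. Compound 1 stands second highest of the three numbers, yet its steps to both others lie within the usual scatter: a 1.8-fold lower number from compound 1 to compound 2 (0.26 log units; within the scatter) and a 1.8-fold higher number from compound 1 to compound 3 (0.25 log units; within the scatter) in turn.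

Compound 4 `COc1cc(C#N)cnc1C(=O)Nc1ccc(F)c([C@]2(C)C=C(CF)OC(N)=N2)c1` has not been measured. Its change is methoxy in place of chloro on an aromatic carbon and this sits on a six-membered aromatic ring with 1 nitrogen, meta to a cyano group.

Among the compounds with values here, no measured compound carries the methoxy, so no step shows its effect directly. The closest evidence is the loss of the chloro in going to compound 2, the first step above, which stays within the scatter. A larger swap of the whole group, a 3.3-fold higher number from compound 2 to compound 3 (0.52 log units; beyond the scatter) here, goes beyond the scatter but replaces far more than compound 4 does. In this assay no step beyond the scatter is therefore expected, and no direction can be favoured.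

The expected change is a 1.1-fold lower number from compound 1 to compound 4 (0.04 log units; within the scatter) as an estimate. For compound 4 the estimated value is 28 mL/min/kg with an expected range from 14 mL/min/kg to 55 mL/min/kg in this estimate.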

Compound 4, clearance: 36.6 mL/min/kg
For compound 4 the middle estimate is 1.3-fold (0.12 log units) below the measured one; low and high end bracket the measured number.
By their numbers in this assay, from the lowest: compounds 2, 1, 4 and 3 (each within the scatter of the next, the first and the last beyond it).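

In this assay, the direct swap at this position, on an aromatic carbon ortho to a large group, gives a 1.2-fold higher number from compound 1 to compound 4 (0.08 log units; within the scatter) and so shows that methoxy and chloro cannot be told apart here. Measured against hydrogen at the same carbon, methoxy gives a 2.2-fold higher number from compound 2 to compound 4 (0.34 log units; beyond the scatter) as a modest step beyond the scatter, something the loss of chloro alone did not show, since that step stayed within it. Replacing the whole 2-(fluoromethyl)-1,3-oxazol-4-yl group with 5-cyano-3-methoxypyridin-2-yl gives a 1.5-fold lower number from compound 3 to compound 4 (0.18 log units; within the scatter) and stays within the scatter, so the methoxy amide cannot be separated from the oxazole amide, although the amide with hydrogen at this carbon can.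

Nothing measured here accounts for why clearance differs between methoxy and hydrogen at this carbon. On these data alone, it remains open whether a fluoro, an amine or a longer chain such as ethoxy at this carbon would stay level with chloro and methoxy or come closer to hydrogen.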